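The source may report more compounds than this note shows. Statements on the series, on what has been measured and on what is new or still open speak of the compounds shown alone.

Compound 3 `CC[C@H]1CN(c2ncc(C(N)=O)nc2Cl)CCN1C1CCN(C(=O)c2ccc(Cl)nc2N)CC1` gives 2.5 nM in an in vitro assay on BaF3 cells for displacement of a labelled ligand from C-X-C chemokine receptor type 3 (Homo sapiens) (a higher number here means a weaker inhibitor, a lower number a stronger inhibitor), the second highest of three numbers. Compound 1 `CC[C@H]1CN(c2nc(N)c(C(=O)NCCNS(N)(=O)=O)nc2Cl)CCN1C1CCN(Cc2ccc(Cl)cc2)CC1` gives 1.9 nM, within the scatter of compound 3, and compound 2 `CC[C@H]1CN(c2nc(N)c(C(=O)NCCS(C)(=O)=O)nc2Cl)CCN1C1CCN(Cc2ccc(Cl)cc2)CC1` gives 6.4 nM, beyond the scatter. For the measured compounds named here, the single measured step, a 3.4-fold higher number from compound 1 to compound 2 (0.53 log units; beyond the scatter), concerns a different part of the molecule from the amide-type nitrogen changed here, so it gives no direct guide. Compound 4 `CC[C@H]1CN(c2ncc(C(=O)NC3CC3)nc2Cl)CCN1C1CCN(C(=O)c2ccc(Cl)nc2N)CC1` carries cyclopropyl in place of hydrogen on an amide-type nitrogen. Going by the values given here, no measured step bears on this change, and nothing in the set points to a direction. The step expected here, a 1.2-fold higher number from compound 3 to compound 4 (0.08 log units; within the scatter), is none beyond the scatter. Compound 4 is estimated at 3 nM, with a range from 1 nM to 9 nM.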

Compound 4, half-maximal inhibitory concentration: 1.2 nM
Estimate against measurement, compound 4: 2.5-fold (0.40 log units) above; the measured number falls inside the stated range.
By their numbers in this assay, from the lowest: compounds 4, 1 and 3 (each within the scatter of the next, the first and the last beyond it); then compound 2.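

With cyclopropyl in place of hydrogen on the amide-type nitrogen, the number falls modestly, a 2.1-fold lower number from compound 3 to compound 4 (0.32 log units; beyond the scatter), so this nitrogen need not keep its hydrogen for activity to hold. For the compounds shown here, the cyclopropylcarbamoyl group is accepted here in place of carbamoyl, and the step is the first measured at this position. No available data bear on why the number falls. From the compounds shown here alone, whether methyl, cyclobutyl or a longer chain on the same nitrogen gives a similar step remains open. So does whether cyclopropyl has the same effect on the core of compound 1.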